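The source may hold more compounds than are shown below. What is called first, only, known or untested is meant among the compounds shown, and "the series" means these compounds.

Compound 1 `CC(C)=CCC1Cc2c(OCCCNS(=O)(=O)c3ccc([N+](=O)[O-])cc3)cc(=O)n(CCCO)c2CC1(C)C` and compound 2 `CC(C)=CCC/C(C)=C/CC1Cc2c(OCCCNS(=O)(=O)c3ccc(Cl)cc3)cc(=O)n(CCCO)c2CC1(C)C` share one core and were both run in a functional assay on PANC-1 cells (Homo sapiens) for inhibition, read by MTT assay, with a stated time of 24 h, tested at 10 uM; a higher number here means more inhibition at the concentration tested (going by the name of the read-out), a lower number less inhibition. In this assay compound 1 gives 47.7%, while compound 2 gives 14.5%, the lower of the two numbers and separated from compound 1 by a gap beyond the usual scatter. Compound 3 `CC(C)=CCC/C(C)=C/CC1Cc2c(OCCCNS(=O)(=O)c3ccc([N+](=O)[O-])cc3)cc(=O)n(CCCO)c2CC1(C)C` arises from compound 2 by a single change: nitro in place of chloro on an aromatic carbon. Compound 1, which also carries a nitro group, gives 47.7%. On that basis the step in this assay is expected to be upward and of modest size, a number 13.5 percentage points higher from compound 2 to compound 3 (beyond the scatter). Compound 3 is therefore estimated at 28%, within 12% to 48%.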

Compound 3, a percentage reported as inhibition, at one concentration (the size of the read-out at that concentration, not a potency): 7.4%
Estimate against measurement, compound 3: 20.6 percentage points above; measured number outside the range, below it.
By their numbers in this assay, from the lowest: compounds 3 and 2 (each within the scatter of the next); then compound 1.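

In this assay the swap of chloro for nitro on the aromatic carbon gives a number 7.1 percentage points lower from compound 2 to compound 3 (within the scatter) and so shows no difference beyond the usual scatter on this side chain. With nitro held constant, the side chain counts for far more: 3-methylbut-2-en-1-yl in place of hydrogen gives a number 40.3 percentage points lower from compound 1 to compound 3 (beyond the scatter) as the large step here. Within the data shown here, nothing measured so far explains this step. Still open, on these data alone, is whether an amine or a carboxylic acid at that aromatic carbon would shift the number, and whether chloro and nitro also match on the shorter side chain of compound 1.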